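Sulfonyl Series, Aryl Halide Swap: Notes Before Measurement

A few compounds are considered here, and "the series" means these few. Any claim that something is new, unique, unknown or untested is made for them only; others in the source may bear on it.

Measured so far:
- compound 1 `CN(C)CCn1cc(S(=O)(=O)c2ccccc2)c2cccnc21`: 94%
- compound 2 `NCCn1cc(S(=O)(=O)c2cccc(F)c2)c2ncccc21`: 51%

In a functional assay on HeLa cells for agonist activity at 5-hydroxytryptamine receptor 6 (Homo sapiens), read by cAMP accumulation and immunoassay (a lower number here means a smaller maximal response, a higher number a larger maximal response), compound 2 gives 51%, the lowest of the two numbers available. Its nearest neighbour is compound 1, which in this assay gives 94%, a gap that lies beyond the usual scatter. For the measured compounds named here, no single-change step between measured compounds exists, so nothing tells how the aryl halide itself moves the maximal response.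

Compound 3 `NCCn1cc(S(=O)(=O)c2cccc(Cl)c2)c2ncccc21` is the next entry. Relative to compound 2 the change is chloro in place of fluoro on an aromatic carbon; cut one bond further out, 3-fluorophenyl becomes 3-chlorophenyl, with the aminoethyl chain and the shared core unchanged.

With only two measured points and no halide comparison among them, the working expectation is a step from compound 2 to compound 3 of a number 4 percentage points higher from compound 2 to compound 3 (within the scatter), that is none beyond the scatter. Compound 3 in this assay is therefore estimated at 55%, within 35% to 75%.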

Compound 3, largest response reached (reported as Imax), in percent of the reference or control that the assay uses: 56%
Compound 3: the middle estimate sits 1 percentage points below what was measured; low and high end bracket the measured number.
By their numbers in this assay, from the lowest: compounds 2 and 3 (each within the scatter of the next); then compound 1.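

In this assay, chloro in place of fluoro on an aromatic carbon, meta to a large group, gives a number 5 percentage points higher from compound 2 to compound 3 (within the scatter), the first single-change step available in the series. At this position, 3-fluorophenyl and 3-chlorophenyl therefore cannot be told apart by maximal response, with the aminoethyl chain and the shared core held constant. No measurement available here bears on the reason for this result.

The compounds shown cover only these two halogens at this place, so it remains open whether bromo, trifluoromethyl, methoxy or a nitrile would stay level with them or shift the maximal response beyond the scatter. Also open, from the compounds shown here alone, is whether the halide swap would read the same with a longer chain or a dimethylamino group on the aminoethyl chain.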